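Shorter Chains on the Shared Core

The compounds below may be only part of what the source reports. "The series", "measured", "known", "first", "only" and "open" are said of these compounds alone.

Compound 2 `CCCN(CCC)c1nc(C)nc(N(CC)c2ccc(N(C)C)cc2C(F)(F)F)n1` has been tested in an assay on isolated protein for binding affinity to corticotropin-releasing factor receptor 1 (Homo sapiens); a higher number here means a weaker inhibitor, a lower number a stronger inhibitor; in this assay compound 2 gives 6 nM. Its closest relative is compound 1 `CCCCN(CC#N)c1nc(C)nc(N(CC)c2ccc(N(C)C)cc2C(F)(F)F)n1`, which in this assay gives 6 nM, so compound 2 stands level with compound 1 within the scatter. Within the data shown here, the only measured step, no change at the digits printed from compound 1 to compound 2 (within the scatter), swaps one pair of chains on the amine attached to the shared core for another pair and leaves the read-out unchanged.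

Compound 3 `CCN(CC)c1nc(C)nc(N(CC)c2ccc(N(C)C)cc2C(F)(F)F)n1` has not yet been measured. It differs from compound 2 in one place: diethylamino in place of dipropylamino on an aromatic carbon, so each chain on that amine becomes shorter while the amine itself stays. The step from compound 1 to compound 2 bears on this change, since it also altered only that amine and was flat. The expected step is therefore small, a 1.3-fold higher number from compound 2 to compound 3 (0.12 log units; within the scatter), meaning no change beyond the scatter. Compound 3 is expected to give about 8 nM in this assay, with a likely range from 3 nM to 25 nM.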

Compound 3, inhibition constant: 20 nM
Estimate against measurement, compound 3: 2.5-fold (0.40 log units) below; low and high end bracket the measured number.
By their numbers in this assay, from the lowest: compounds 1 and 2 (each within the scatter of the next); then compound 3.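

In this assay, the amine on the shared core proves not to be indifferent to its chains, something the earlier pair could not show: the swap from butyl(cyanomethyl)amino to dipropylamino was flat, with no change at the digits printed from compound 1 to compound 2 (within the scatter), whereas diethylamino in place of dipropylamino gives a 3.3-fold higher number from compound 2 to compound 3 (0.52 log units; beyond the scatter). Measured against the other earlier compound, the result is the same, with a 3.3-fold higher number from compound 1 to compound 3 (0.52 log units; beyond the scatter), so diethylamino stands apart from both larger amines, which remain level with each other. Among these three compounds, then, the position accepts one exchange of chains without a measurable change, but shortening both chains by one carbon each brings a modest weakening that rises beyond the usual scatter.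

Going by these compounds, whether a still shorter pair, as in dimethylamino, would weaken binding further, and whether a longer pair, as in dibutylamino, or a ring amine such as pyrrolidine would hold the level of compound 2, remains open. No measurement available here accounts for why this step weakens binding when the earlier exchange did not.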